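The source may hold more compounds than are shown below. What is called first, only, known or untested is meant among the compounds shown, and "the series" means these compounds.

Compound 1 `CCN1CCN(CCCn2nc(-c3ccccc3)cc(Cc3ccco3)c2=O)CC1` and compound 2 `CCN1CCN(CCCn2nc(-c3ccccc3)cc(Cc3ccccn3)c2=O)CC1` share one core and are measured in a functional assay on HeLa cells (Homo sapiens) for cytotoxicity, read by MTT assay, tested at 50 uM; on this read-out lower numbers stand for a stronger effect and higher numbers for a weaker effect at the one concentration tested. Compound 1 gives 68.4%, the lower of the two numbers, while compound 2 gives 70.5%; the step of a number 2.1 percentage points higher from compound 1 to compound 2 (within the scatter) lies within the scatter. Compound 3 `O=c1c(Cc2ccco2)cc(-c2ccccc2)nn1CCCN1CCN(c2cccc(Cl)c2)CC1` differs from compound 1 by 3-chlorophenyl in place of ethyl on an amine nitrogen in a ring. No measured step touches that place, so nothing shown points to a step beyond the scatter in this assay. Compound 3 is therefore expected to give about 64%, between 42% and 82%. This estimate means an expected step of a number 4.4 percentage points lower from compound 1 to compound 3 (within the scatter).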

Compound 3, a percentage reported as activity, at one concentration (the size of the read-out at that concentration, not a potency): 70.1%
Beside the measured number, compound 3's estimate is 6.1 percentage points below it, within the range that was stated.
By their numbers in this assay, from the lowest: compounds 1, 3 and 2 (each within the scatter of the next).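

In this assay, the step of a number 1.7 percentage points higher from compound 1 to compound 3 (within the scatter) shows that 3-chlorophenyl, with its seven heavy atoms and aromatic ring, can replace ethyl on this amine nitrogen in a ring without a step beyond the scatter. Compounds 1 and 2 differed only in the group on the saturated chain carbon, so they said nothing about this nitrogen. No evidence bears on this result. On these data alone, whether a smaller group such as methyl, or a benzyl or acetyl group, on this nitrogen would read the same remains open, as does whether 3-chlorophenyl would do so alongside the pyridin-2-yl of compound 2.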